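The source may hold more compounds than are shown below. What is called first, only, known or untested is meant among the compounds shown, and "the series" means these compounds.

Series notes. Compound 1 `Cc1c(C(=O)N/N=C\c2cccc(O)c2)oc2cccc(O)c12` carries 3-hydroxyphenyl on the carbon with a double bond to nitrogen; in a functional assay on PC-3 cells (Homo sapiens) for inhibition (on this read-out higher numbers stand for weaker inhibition and lower numbers for stronger inhibition), compound 1 gives 17600 nM. Compound 2 `Cc1c(C(=O)N/N=C\c2ccccc2F)oc2cccc(O)c12` in this assay reaches only a limit of the assay, >= 40000 nM, not a number. Compound 3 `Cc1c(C(=O)N/N=C\c2ccc(F)cc2)oc2cccc(O)c12` in this assay likewise reports only a limit, >= 40000 nM, so compound 3 sits at the limit of >= 40000 nM in this assay, at which 2 of the 3 values shown sit. Compound 4 `Cc1c(C(=O)N/N=C\c2cccnc2)oc2cccc(O)c12` differs from compound 3 in that (pyridin-3-yl in place of 4-fluorophenyl on a carbon with a double bond to nitrogen). Within the data shown here, the steps touching compound 3 are an at least 2.2-fold higher number from compound 1 to compound 3 (0.35 log units; beyond the scatter) and a step that the two limits leave unreadable from compound 2 to compound 3; neither involves a pyridin-3-yl group, and compound 1 supplies the only numeric value. For compound 4 the expected step is an at least 1.1-fold lower number from compound 3 to compound 4 (0.05 log units; that floor lies within the scatter), with a real chance of another limit. Compound 4 is estimated at 35000 nM in this assay, range 12000 nM to 80000 nM.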

Compound 4, half-maximal inhibitory concentration: >= 40000 nM
Compound 4: only a limit was reported; the forecaster's own chance of this, stated with the estimate: 55%; middle value at least 1.1-fold (0.05 log units) from the limit.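

Pyridin-3-yl brings a ring hetero atom and a hydrogen-bond acceptor to the carbon with a double bond to nitrogen, yet in this assay compound 4 also reports only a limit of the assay: the limit of >= 40000 nM in this assay, at which 3 of the 4 values shown sit.

Replacing 3-hydroxyphenyl with pyridin-3-yl gives an at least 2.2-fold higher number from compound 1 to compound 4 (0.35 log units; beyond the scatter), so this hydrogen-bond acceptor does not reach the numeric result of compound 1. The steps to compound 4 from compound 2 and compound 3 cannot be read, as both ends are limits.

As far as these compounds go, it remains open whether an amine or a carboxylic acid in place of the hydroxyl group of compound 1 would give a numeric value. From the compounds shown here alone, the true values of compound 2, compound 3 and compound 4 also remain unknown.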